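The source may report more compounds than this note shows. Statements on the series, on what has been measured and on what is new or still open speak of the compounds shown alone.

Three measured compounds share one core and differ only in their outer groups. Compound 1 `CC#C[C@@H](Cc1nnn[nH]1)c1ccc(OCc2cc(C)c3scc(-c4ccccc4C)c3c2)cc1` gives 134 nM in a functional assay on cells for agonist activity at Free fatty acid receptor 1 (Homo sapiens), read by FLIPR and calcium flux (on this read-out higher numbers stand for an effect only at larger amounts of compound and lower numbers for an effect already at smaller amounts), compound 2 `CC#C[C@@H](Cc1nnn[nH]1)c1ccc(OCc2ccc3scc(-c4ccc(OCCC(C)(C)O)cc4C)c3c2)cc1` gives 8 nM, and compound 3 `CC#C[C@@H](Cc1nnn[nH]1)c1ccc(OCc2ccc3sc(F)c(-c4ccccc4C)c3c2)cc1` gives 15 nM. Compound 3 thus stands second highest of the three: its number sits close to that of compound 2, within the usual scatter, while the gap to compound 1 lies beyond it.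

Compound 4 `CC#C[C@@H](Cc1nnn[nH]1)c1ccc(OCc2ccc3sc(C)c(-c4ccccc4C)c3c2)cc1` is compound 3 with one change: methyl in place of fluoro on an aromatic carbon. Within the data shown here, no measured pair shows this exchange, so nothing here sets a direction. The expected step in this assay from compound 3 to compound 4 is a 1.3-fold higher number from compound 3 to compound 4 (0.12 log units; within the scatter), none beyond the scatter. Compound 4 is therefore estimated at 20 nM, in a range from 6 nM to 65 nM.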

Compound 4, half-maximal effective concentration: 20 nM
Compound 4: middle estimate and measured number agree at the digits printed; low and high end bracket the measured number.
By their numbers in this assay, from the lowest: compounds 2, 3 and 4 (each within the scatter of the next, the first and the last beyond it); then compound 1.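

On the aromatic carbon next to the ring sulfur, methyl in place of fluoro gives in this assay a 1.3-fold higher number from compound 3 to compound 4 (0.12 log units; within the scatter), so on this evidence the two groups cannot be told apart at this position. Among these compounds, the earlier compounds offered no pair differing in one place, so this is the first direct reading of any single exchange on the shared core. Nothing measured here offers an explanation for this result. As far as these compounds go, whether an amine, a methoxy group or a longer chain on this carbon would give a similar number remains open.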